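Working notes: extending the amine side chain

The source may hold more compounds than are shown below. What is called first, only, known or untested is meant among the compounds shown, and "the series" means these compounds.

Measured compounds:
compound 1 `Cn1cc(C2=C(c3cccc4ccc(CN)cc34)C(=O)NC2=O)c2ccccc21`: > 316 nM
compound 2 `CNCc1ccc2ccc(Cl)c(C3=C(c4cn(C)c5ccccc45)C(=O)NC3=O)c2c1`: 15 nM

Of the compounds shown here, two have been measured. In an assay on isolated protein for inhibition of protein kinase C delta type (Homo sapiens), read by scintillation proximity assay and 33P incorporation, with a stated time of 60 min, in the presence of a further agent that is not named here (on this read-out higher numbers stand for weaker inhibition and lower numbers for stronger inhibition), compound 1 gives > 316 nM; this is a limit of the assay and not a number, namely (the limit of > 316 nM in this assay, at which 1 of the 2 values shown sits). In this assay, within the data shown here, compound 2 gives 15 nM, the only defined number in the set, so compound 2 stands alone as the one compound with a measured value rather than a limit. Among the measured compounds shown here, no step between measured compounds that differ in one place exists here; compound 1 and compound 2 differ in more than one place, and their values show only that one sits at a limit while the other returns a number.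

Compound 3 `COCCNCc1ccc2ccc(Cl)c(C3=C(c4cn(C)c5ccccc45)C(=O)NC3=O)c2c1` is not yet measured. It differs from compound 2 by methoxymethyl in place of hydrogen on a saturated chain carbon bound to an amine nitrogen. For the measured compounds named here, no measured step of this kind is available, so the expectation rests on compound 2 alone. A small step is expected, within the scatter or at most slightly toward weaker inhibition, estimated as a 1.7-fold higher number from compound 2 to compound 3 (0.22 log units; within the scatter). Compound 3 is expected to give 25 nM in this assay, with an estimated range from 8 nM to 80 nM.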

Compound 3, half-maximal inhibitory concentration: 39 nM
Compound 3: middle estimate off by 1.6-fold (0.19 log units), on the low side; measured number inside the range.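

In this assay, among these compounds, the change from (methylamino)methyl to ((2-methoxyethyl)amino)methyl gives the first measured step at this place, on a saturated chain carbon bound to an amine nitrogen, and it reads as a 2.6-fold higher number from compound 2 to compound 3 (0.41 log units; beyond the scatter) for this pair. The step is modest but beyond the scatter, so this place is not indifferent to the change, even though compound 3 still returns a defined number, 39 nM, and not a limit of the assay. No measurement shown bears on what lies behind this step, which rests on a single pair of compounds.

Going by these compounds, whether the step follows the added chain length or the ether oxygen stays open, and a propyl group in place of the 2-methoxyethyl group on the same amine nitrogen would separate the two. Also open, on these data alone, is how far the place accepts further change, for example a longer chain, a terminal hydroxyl group, a carboxylic acid or a second amine at the end of the chain, as read in this assay.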